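From a Sulfur-Bearing Side Chain to a Carboxy Group

The source may hold more compounds than are shown below. What is called first, only, known or untested is meant among the compounds shown, and "the series" means these compounds.

Measured so far:
Compound 1 `CCCCCCCCCCCCCCCCCCOC1=C(O)[C@@H](C(O)CO)OC1=O` gives 6000 nM in a functional assay (brain) for inhibition, with Rattus norvegicus as the target; on this read-out lower numbers stand for stronger inhibition and higher numbers for weaker inhibition.
Compound 2 `Cc1c(C)c2c(c(C)c1O)CC[C@](C)(CC[S+](C)C)O2` gives 2000 nM in this assay.
Compound 3 `Cc1c(C)c2c(c(C)c1O)CC[C@@](C)(CC[S+](C)C)O2` gives 2000 nM in this assay.

Compound 2 stands level with compound 3, the two together giving the lowest numbers of the three, while compound 1 lies furthest away with a higher number. Compound 2 and compound 3 differ only in configuration at one ring carbon (the fact that compounds 2 and 3 differ only in the configuration as drawn), and the step of no change at the digits printed from compound 2 to compound 3 (within the scatter) shows no effect of that. The unmeasured compound 4 `Cc1c(C)c2c(c(C)c1O)CC[C@](C)(CC(=O)O)O2` differs from compound 2 by a group of 3 heavy atoms (1 carbon, 2 oxygen; no ring) in place of a group of 4 heavy atoms (3 carbon, 1 sulfur; no ring), on a saturated chain carbon bound to a saturated ring carbon. For the measured compounds named here, no measured step alters a side group in this way; the only step on record concerns configuration alone, so it offers no guide to direction or size. Compound 4 is expected to stay near compound 2, with wide uncertainty, the step being estimated as a 1.5-fold higher number from compound 2 to compound 4 (0.18 log units; within the scatter). Compound 4 is estimated at 3000 nM, between 600 nM and 15000 nM.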

Compound 4, half-maximal inhibitory concentration: 14000 nM
For compound 4 the middle estimate is 4.7-fold (0.67 log units) below the measured one, within the range that was stated.
By their numbers in this assay, from the lowest: compounds 2 and 3 (each within the scatter of the next); then compound 1; then compound 4.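

In this assay, the side group on this saturated chain carbon bound to a saturated ring carbon clearly matters: putting carboxy in place of the sulfur-bearing group, which carries a net charge of +1, gives a 7.0-fold higher number from compound 2 to compound 4 (0.85 log units; beyond the scatter). For the compounds shown here, the earlier pair showed only that configuration at the ring carbon made no difference, with no change at the digits printed from compound 2 to compound 3 (within the scatter). Nothing on record gives a reason for the new step.

Still open, on these data alone, is how an amine or a longer chain ending in carboxy would read at this place. Also open, as far as these compounds go, is whether configuration stays without effect once carboxy is present.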